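The source may report more compounds than this note shows. Statements on the series, on what has been measured and on what is new or still open speak of the compounds shown alone.

The compounds were compared in a functional assay on UACC-62 cells (Homo sapiens) for inhibition, read by sulforhodamine B assay, with a stated time of 48 h; on this read-out lower numbers stand for stronger inhibition of growth and higher numbers for weaker inhibition of growth. Compound 2 `Nc1nn(C(=O)Nc2ccc(Cc3ccccc3)cc2)c2ccccc12` gives 353 nM, the lower of the two measured numbers. Compound 1 `O=C(Nc1ccc(Cc2ccccc2)cc1)Nc1nn(C(=O)Nc2ccc(Cc3ccccc3)cc2)c2ccccc12`, which carries a second urea on the shared core, gives 41600 nM, and the gap to compound 2 lies beyond the scatter. Compound 3 `COc1ccccc1NC(=O)n1nc(N)c2ccccc21` returns > 100000 nM, which is a limit of the assay and not a number. That point is the limit of > 100000 nM in this assay, at which 1 of the 3 values shown sits. Compound 4 `CCCCOc1ccc(NC(=O)n2nc(N)c3ccccc32)cc1` has not yet been measured; it differs from compound 2 by butoxy in place of benzyl on an aromatic carbon. Among the measured compounds shown here, no measured pair shows this change. The expected step is a 4.2-fold higher number from compound 2 to compound 4 (0.63 log units; beyond the scatter), a modest weakening that may still fall within the scatter. Compound 4 is estimated at 1500 nM, with a range from 300 nM to 8000 nM.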

Compound 4, concentration for 50% growth inhibition: 14700 nM
Compound 4: the middle estimate sits 9.8-fold (0.99 log units) below what was measured, outside the stated range (above it).
By their numbers in this assay, from the lowest: compound 2; then compound 4; then compound 1. At a limit, above all of these: compound 3.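

Replacing benzyl with butoxy on this aromatic carbon, para to a large group, gives a 42-fold higher number from compound 2 to compound 4 (1.62 log units; beyond the scatter) in this assay, the first step read at this position. Growth inhibition here therefore depends strongly on which of these two groups is present, and benzyl gives the lower number. Nothing in the data shown accounts for the size of this step.

Going by these compounds, the step removes the ring and brings in the oxygen at once, so their separate contributions stay open. On these data alone, whether a plain butyl chain or a benzyloxy group would behave like benzyl or like butoxy also remains unknown.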